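A few compounds are considered here, and "the series" means these few. Any claim that something is new, unique, unknown or untested is made for them only; others in the source may bear on it.

Compound 1 `NC(=O)c1cccc(NC(=O)c2cc(Cl)ccc2O)c1`: > 60000 nM
Compound 2 `O=C(Nc1ccccc1)c1cccc(NC(=O)c2cc(Cl)ccc2O)c1`: > 60000 nM
Compound 3 `NC(=O)c1ccc(NC(=O)c2cc(Cl)ccc2O)cc1`: > 60000 nM

All three values come from an ADME assay on cells (Macrophage, Mus musculus) for cytotoxicity, read by resazurin assay, with a stated time of 3 days; on this read-out lower numbers stand for stronger inhibition and higher numbers for weaker inhibition. In this assay compound 1 gives only a limit, > 60000 nM, not a number. Compound 2 likewise gives only a limit, > 60000 nM. Compound 3 also stops at a limit, > 60000 nM. The change from compound 1 to compound 2 is phenyl in place of hydrogen on an amide-type nitrogen; its step that the two limits leave unreadable from compound 1 to compound 2 cannot be sized because both ends sit at the limit of > 60000 nM in this assay, at which 3 of the 3 values shown sit. How the core of compound 3 differs from that of compound 1 is not broken down here.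

Compound 4 `O=C(Nc1ccccc1)c1ccc(NC(=O)c2cc(Cl)ccc2O)cc1` is not yet measured. It differs from compound 3 by phenyl in place of hydrogen on an amide-type nitrogen, the same change. The step from compound 3 to compound 4 is expected to be a step that the limit leaves unreadable from compound 3 to compound 4 because every measured compound sits at the limit of > 60000 nM in this assay, at which 3 of the 3 values shown sit. Compound 4 is therefore expected to give 100000 nM, most likely again only a limit.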

Compound 4, half-maximal inhibitory concentration: > 60000 nM
Compound 4: only a limit was reported; the forecaster's own chance of this, stated with the estimate: 90%; the middle value lies beyond the limit too.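

Compound 3 and compound 4 both give only a limit, so the size of the step between them cannot be read: the limit of > 60000 nM in this assay, at which 4 of the 4 values shown sit.

The compounds shown leave open at what concentration any of them would harm these cells, and whether the added phenyl changes that.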